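Isopropoxy to isobutoxy on the benzamide of a pyrazole acid

This account rests on a few compounds, and the source may have more. Where it says the series, first, only, none or still open, it means among the compounds named here.

Measured compounds:
compound 1 `CCOc1ccc(-c2c(NC(=O)c3ccc(OCC(C)C)cc3)c(C(=O)O)nn2-c2ccc(Oc3ccccc3)cc2)cc1` gives 446 nM
compound 2 `CC(C)Oc1ccc(C(=O)Nc2c(C(=O)O)nn(-c3ccc(Oc4ccccc4)cc3)c2-c2ccc(OC(C)C)cc2)cc1` gives 107 nM

Both compounds were tested in an assay for displacement of a labelled ligand from E3 ubiquitin-protein ligase Mdm2 (Homo sapiens), read by fluorescence polarization, with a stated time of 30 min; a lower number here means a stronger inhibitor, a higher number a weaker inhibitor. Of the two numbers shown, compound 2 has the lower one, and the gap to compound 1 is beyond the usual scatter, so compound 2 is the stronger binder of the pair. Compound 1 and compound 2 differ in more than one place, so no single change can be credited for that gap.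

Compound 3 `CC(C)COc1ccc(C(=O)Nc2c(C(=O)O)nn(-c3ccc(Oc4ccccc4)cc3)c2-c2ccc(OC(C)C)cc2)cc1` has not yet been measured. It differs from compound 2 by isobutyl in place of isopropyl on an oxygen on an aromatic ring. Compound 1 already carries the isobutoxy group at this position, together with a different group on the other phenyl ring, and its value sits above that of compound 2, which gives some reason to expect that compound 3 will not improve on compound 2. Among the measured compounds shown here, with no directly comparable step available, a modest weakening is expected, on the order of a 1.9-fold higher number from compound 2 to compound 3 (0.27 log units; within the scatter). The value for compound 3 in this assay is therefore estimated at 200 nM, with a plausible range from 70 nM to 600 nM.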

Compound 3, inhibition constant: 422 nM
The estimate for compound 3 lay 2.1-fold (0.32 log units) below the measured number; low and high end bracket the measured number.
By their numbers in this assay, from the lowest: compound 2; then compounds 3 and 1 (each within the scatter of the next).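

Swapping isopropoxy for isobutoxy on the benzamide, with everything else held fixed, gives a 3.9-fold higher number from compound 2 to compound 3 (0.60 log units; beyond the scatter) in this assay, so this position responds to a small change in the shape of its chain, and isopropoxy is the better of the two groups here. The other change, methyl in place of hydrogen on a saturated chain carbon bound to an oxygen on an aromatic ring and a saturated chain carbon, gives a 1.1-fold lower number from compound 1 to compound 3 (0.02 log units; within the scatter), which is within the scatter and shows no measurable effect in this pair, where both compounds carry isobutoxy on the benzamide. Nothing available explains why isobutoxy gives the higher number at this position.

On these data alone, the isopropoxy-to-isobutoxy step has been read only once, on a single background, so its size with a different group on the other phenyl ring remains unknown. The compounds shown also leave open how this position would respond to a methoxy group, a cyclopentyloxy ring, a longer chain or a chain ending in an amine.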